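Amide for Diamine: What to Expect for Compound 4

This account rests on a few compounds, and the source may have more. Where it says the series, first, only, none or still open, it means among the compounds named here.

In an assay on isolated protein (urine) for inhibition of Myeloperoxidase (Homo sapiens), with a stated time of 5 min (a lower number here means a stronger inhibitor, a higher number a weaker inhibitor), compound 1 `NCCCCc1c[nH]c2c(F)cccc12` gives 6 nM. Compound 2 `NCC(N)CCc1c[nH]c2ccc(F)cc12` gives 60 nM in this assay, the highest of the two numbers shown, with compound 1 the nearest. Compound 3 `NCCSCCCc1c[nH]c2c(F)cccc12` gives > 100 nM in this assay, which is a limit of the assay and not a number (the limit of > 100 nM in this assay, at which 1 of the 3 values shown sits). For the measured compounds named here, the single measured step, an at least 16-fold higher number from compound 1 to compound 3 (1.22 log units; beyond the scatter), likewise exchanged one amine-containing group for another. Compound 4 `NC(=O)CCCc1c[nH]c2ccc(F)cc12` carries carbamoylmethyl in place of 1,2-diaminoethyl on a saturated chain carbon, two bonds along the chain from an aromatic carbon. Going by the values given here, that step is the only guide available, and it was large, so a weaker result is expected for compound 4, quite possibly ending at a limit again. Compound 4 is estimated at 300 nM, between 60 nM and 3000 nM, an expected step of a 5.0-fold higher number from compound 2 to compound 4 (0.70 log units; beyond the scatter).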

Compound 4, half-maximal inhibitory concentration: 18 nM
Estimate against measurement, compound 4: 17-fold (1.22 log units) above; measured number below the stated range.
By their numbers in this assay, from the lowest: compound 1; then compound 4; then compound 2. At a limit, above all of these: compound 3.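

In this assay, for the compounds shown here, swapping 1,2-diaminoethyl for carbamoylmethyl at this chain carbon gave a 3.3-fold lower number from compound 2 to compound 4 (0.52 log units; beyond the scatter) and so moved the number down, whereas the only earlier step, an at least 16-fold higher number from compound 1 to compound 3 (1.22 log units; beyond the scatter), moved it up. A low number at this position therefore does not depend on the 1,2-diaminoethyl group, and a chain ending in an amide can serve in its place. Nothing measured here explains why the amide gives the lower number.

On these data alone, it remains open whether a carboxylic acid would serve as well at this chain end. A longer chain carrying the same amide is also untested in the compounds shown, so how far the amide tolerates a change in chain length cannot be said.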